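Methyl for Chloro at the Cytotoxicity Limit

The compounds below may be only part of what the source reports. "The series", "measured", "known", "first", "only" and "open" are said of these compounds alone.

Compound 1 `O=C(O)COc1ccc(/C=C2/SC(=O)N(Cc3ccc(F)cc3)C2=O)cc1Br` gives > 200000 nM in an ADME assay on Vero cells (Chlorocebus sabaeus) for inhibition, read by MTT assay (a lower number here means that less compound is tolerated, a higher number that more compound is tolerated), a limit of the assay rather than a number.
Compound 2 `O=C(C1=C(O)C(=O)N(c2nnc(SCc3ccc(Cl)cc3)s2)C1c1cccc(O)c1)c1cc2ccccc2o1` gives > 200000 nM in this assay, likewise a limit.

Compound 2 thus stands at the limit, as does every value shown (the limit of > 200000 nM in this assay, at which 2 of the 2 values shown sit). Compound 3 `Cc1ccc(CSc2nnc(N3C(=O)C(O)=C(C(=O)c4cc5ccccc5o4)C3c3cccc(O)c3)s2)cc1` differs from compound 2 by methyl in place of chloro on an aromatic carbon. Within the data shown here, no measured step exists to gauge such a change; with both known values at the limit, no shift beyond the scatter is expected, a number no higher from compound 2 to compound 3 (the limit leaves the size open). Compound 3 is therefore estimated at 200000 nM, within 100000 nM to 400000 nM, most likely again reported as a limit.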

Compound 3, half-maximal cytotoxic concentration: > 200000 nM
Compound 3: no number, only a limit; the forecaster's own chance of this, stated with the estimate: 80%; the middle value lies on the limit itself.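

Compound 2 and compound 3 both stand only as limits in this assay and no step can be read between them. The compounds shown leave open how much compound the cells tolerate, and whether chloro or methyl matters.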